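Swapping the aryl group on the ring nitrogen

A few compounds are considered here, and "the series" means these few. Any claim that something is new, unique, unknown or untested is made for them only; others in the source may bear on it.

Of the compounds shown here, three built on one shared core have been measured in an assay on HEK293 cells for inhibition of Voltage-dependent T-type calcium channel subunit alpha-1G (Homo sapiens), read by fluorescence, tested at 10 uM; a lower number here means less inhibition, a higher number more inhibition at the concentration tested (going by the name of the read-out). Compound 1 `CCCc1nc(-c2ccccc2)c(CNCCCN2CCN(c3ccc(F)cc3)CC2)o1` gives 62.5%, and compound 2 `CCCc1nc(-c2ccccc2)c(CNCCCN2CCN(c3cccc(F)c3)CC2)o1` gives 68.9%; these two lie within the scatter of each other, with a number 6.4 percentage points higher from compound 1 to compound 2 (within the scatter). Compound 3 `CCCc1nc(-c2ccccc2)c(CNCCCN2CCN(c3ccc(OC)cc3)CC2)o1` gives 42.1% and stands lowest of the three: a number 20.4 percentage points lower from compound 1 to compound 3 (beyond the scatter) and a number 26.8 percentage points lower from compound 2 to compound 3 (beyond the scatter), both beyond the scatter.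

Compound 4 `CCCc1nc(-c2ccccc2)c(CNCCCN2CCN(c3cccc(Cl)c3)CC2)o1` has not yet been measured. It differs from compound 3 in one place: 3-chlorophenyl in place of 4-methoxyphenyl on an amine nitrogen in a ring

The two steps that bear on this change are those leading into compound 3. Both introduced the 4-methoxyphenyl group in place of a fluorine-bearing ring, and both lowered the read-out modestly. Of these, a number 26.8 percentage points lower from compound 2 to compound 3 (beyond the scatter) is the closer guide: 3-fluorophenyl is the nearer relative of 3-chlorophenyl. Reversing that step suggests a rise beyond the scatter. Chlorine in place of fluorine has no precedent among these compounds, so the range is kept wide. Compound 4 is therefore expected to give 65%, within 45% to 85%, which would mean an estimated a number 22.9 percentage points higher from compound 3 to compound 4 (beyond the scatter).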

Compound 4, a percentage reported as inhibition, at one concentration (the size of the read-out at that concentration, not a potency): 65.9%
Estimate against measurement, compound 4: 0.9 percentage points below, within the range that was stated.
By their numbers in this assay, from the lowest: compound 3; then compounds 1, 4 and 2 (each within the scatter of the next).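

In this assay the 3-chlorophenyl group on the amine nitrogen falls in with the two fluorine-bearing rings and not with the 4-methoxyphenyl group: chloro in place of fluoro amounts to a number 3 percentage points lower from compound 2 to compound 4 (within the scatter) and the change from 4-fluorophenyl to a number 3.4 percentage points higher from compound 1 to compound 4 (within the scatter). With a number 23.8 percentage points higher from compound 3 to compound 4 (beyond the scatter) as well, the step away from the 4-methoxyphenyl group now holds with chlorine on the ring as it did with fluorine, so it does not depend on fluorine. Nothing available explains these differences.

The compounds shown leave open whether the low number of compound 3 follows the methoxy group itself or its place on the ring, which a 3-methoxyphenyl group would test. They also leave open how a plain phenyl ring or a 4-chlorophenyl group would read at this position.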